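A Triazole Aryl Change in a Weakly Active Series

The compounds below may be only part of what the source reports. "The series", "measured", "known", "first", "only" and "open" are said of these compounds alone.

Measured compounds:
compound 1, `Cc1cccc(-n2nncc2CN2C(=O)C3(C(C#N)=C(N)Oc4c3c3nc5ccccc5nc3c3ccccc43)c3ccccc32)c1`, > 50000 nM
compound 2, `N#CC1=C(N)Oc2c(c3nc4ccccc4nc3c3ccccc23)C12C(=O)N(Cc1cnnn1-c1ccc(F)cc1)c1ccccc12`, > 50000 nM
compound 3, `N#CC1=C(N)Oc2c(c3nc4ccccc4nc3c3ccccc23)C12C(=O)N(Cc1cnnn1-c1cccc(Cl)c1)c1ccccc12`, 43600 nM

In a functional assay on MCF7 cells (Homo sapiens) for antiproliferative activity, read by MTT assay, with a stated time of 48 h (a lower number here means a stronger inhibitor, a higher number a weaker inhibitor), compound 1 gives only a limit of the assay. Compound 2 likewise gives only a limit in this assay. Among the measured compounds shown here, compound 3 is the sole compound of the three with a number, and it stands at the weak end of what this assay can report; the other two values are limits, as the limit of > 50000 nM in this assay, at which 2 of the 3 values shown sit, records. The step of an at least 1.1-fold lower number from compound 2 to compound 3 (0.05 log units; that floor lies within the scatter) is the one that most directly bears on the change now considered, since it also alters the aryl group on the aromatic nitrogen; the step of an at least 1.1-fold lower number from compound 1 to compound 3 (0.05 log units; that floor lies within the scatter) is of the same kind, and the step that the two limits leave unreadable from compound 1 to compound 2 cannot be read at all.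

Compound 4, `N#CC1=C(N)Oc2c(c3nc4ccccc4nc3c3ccccc23)C12C(=O)N(Cc1cnnn1-c1ccc(N)cc1)c1ccccc12`, differs from compound 3 in one place: 4-aminophenyl in place of 3-chlorophenyl on an aromatic nitrogen. For the measured compounds named here, the only readable steps among the measured compounds lie within the scatter, so no step beyond the scatter is expected here either in this assay. Compound 4 is therefore estimated at 45000 nM, with a range from 20000 nM to 100000 nM, which amounts to the expected step of a 1.0-fold higher number from compound 3 to compound 4 (0.01 log units; within the scatter).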

Compound 4, half-maximal inhibitory concentration: > 50000 nM
Compound 4: only a limit was reported; the forecaster's own chance of this, stated with the estimate: 55%; middle value at least 1.1-fold (0.04 log units) from the limit.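

In this assay, putting 4-aminophenyl in place of 3-chlorophenyl on the aromatic nitrogen of the five-membered ring gives an at least 1.1-fold higher number from compound 3 to compound 4 (0.05 log units; that floor lies within the scatter). Among the compounds shown here, the earlier compounds carried only methyl, fluoro or chloro on this aryl ring, so compound 4 is the first to place a hydrogen-bond donor and acceptor here, and it still yields no number; the steps between compounds 1, 2 and 4 cannot be read. Compound 3 therefore remains the only compound with a number, and the series now rests mostly on a single limit: the limit of > 50000 nM in this assay, at which 3 of the 4 values shown sit.

As far as these compounds go, how far the true values of compounds 1, 2 and 4 lie from that limit stays open, so no order among their aryl groups can be told. Also open, from the compounds shown here alone, is whether a carboxylic acid or a methoxy group on this aryl ring, or a longer chain such as an n-butyl group in place of the aryl ring on the aromatic nitrogen, would give a number that stands clear of the scatter from compound 3.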